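Swapping the benzyl for a dichlorobenzyl on an oxime ether

The source may report more compounds than this note shows. Statements on the series, on what has been measured and on what is new or still open speak of the compounds shown alone.

Compound 1 `C(=N/OCc1ccccc1)\c1c(-c2ccc3ccccc3c2)nc2occn12` is an oxime ether whose oxygen carries a benzyl group. For the measured compounds named here, in an assay on HepG2 cells for agonist activity at nuclear receptor subfamily 1 group I member 3 (Homo sapiens), read by a luciferase reporter, with a stated time of 23 h (on this read-out higher numbers stand for an effect only at larger amounts of compound and lower numbers for an effect already at smaller amounts), compound 1 gives 840 nM, the only plain number among the values shown. Compound 2 `Clc1ccc(CO/N=C/c2c(-c3ccc(C4CCCCC4)cc3)nc3sccn23)cc1Cl` shares the oxime ether but differs in its core and in the group on the other side. In this assay compound 2 reaches only > 100000 nM, which is a limit of the assay rather than a measured number, and the limit of > 100000 nM in this assay, at which 1 of the 2 values shown sits, records that one of the two values sits there.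

Compound 3 `Clc1ccc(CO/N=C/c2c(-c3ccc4ccccc4c3)nc3occn23)cc1Cl` is not yet measured. It differs from compound 1 in one place: 3,4-dichlorophenyl in place of phenyl on a saturated chain carbon bound to an oxygen. Going by the values given here, since compound 2 also differs from compound 3 in other places, its limit gives no step that can be carried over, so the size of the change has to be guessed.

The expectation is a moderate loss of potency, a step of a 3.0-fold higher number from compound 1 to compound 3 (0.47 log units; beyond the scatter), for compound 3. Compound 3 is estimated at 2500 nM, with a likely range from 400 nM to 30000 nM.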

Compound 3, half-maximal effective concentration: 370 nM
Beside the measured number, compound 3's estimate is 6.8-fold (0.83 log units) above it; measured number outside the range, below it.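

In this assay, replacing benzyl with 3,4-dichlorobenzyl gives a 2.3-fold lower number from compound 1 to compound 3 (0.36 log units; beyond the scatter) and nothing else in the molecule changes, so this place on the oxime ether accepts two added chlorine atoms with a modest gain in potency rather than a loss. The earlier compounds shown here could not show this: they differ in several places at once, and no step could be read between them, whereas this pair isolates the effect of one group on the shared core. Nothing measured here explains why the dichlorinated ring gives the lower number.

On these data alone, it remains open whether a single chlorine on the benzyl ring would give part of this gain or whether both chlorine atoms are needed. As far as these compounds go, it is also open how far this place tolerates quite different groups, such as an amine or a carboxylic acid on the ring, or a longer chain between the ring and the oxygen, and whether the same swap would have a similar effect on a different core.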